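Naphthoyl in place of dimethoxybenzoyl on the most potent amide

A few compounds are considered here, and "the series" means these few. Any claim that something is new, unique, unknown or untested is made for them only; others in the source may bear on it.

Measured compounds: compound 1 `CCCCCCOc1cc(NC(=O)c2ccc3ccccc3c2)ccc1N(C)S(C)(=O)=O` gives 64300 nM; compound 2 `Cc1ccc(C(F)(F)F)cc1COc1cc(NC(=O)c2ccc3ccccc3c2)ccc1N(C)S(C)(=O)=O` gives 18400 nM; compound 3 `COc1ccc(OC)c(COc2cc(NC(=O)c3ccc(OC)c(OC)c3)ccc2N(C)S(C)(=O)=O)c1` gives 2.61 nM, all in a functional assay on SK-BR-3 cells (Homo sapiens) for antiproliferative activity, read by MTT assay, with a stated time of 48 h; on this read-out lower numbers stand for stronger inhibition and higher numbers for weaker inhibition.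

Compound 3 holds the lowest number of the three, far beyond the scatter from both compound 2 and compound 1. Among the compounds with values here, the only single-place step measured, a 3.5-fold lower number from compound 1 to compound 2 (0.54 log units; beyond the scatter), concerns the ether side of the shared core and does not touch the amide.

Compound 4 `COc1ccc(OC)c(COc2cc(NC(=O)c3ccc4ccccc4c3)ccc2N(C)S(C)(=O)=O)c1` differs from compound 3 by naphthalen-2-yl in place of 3,4-dimethoxyphenyl on a carbonyl carbon. Within the data shown here, no measured step bears on this change directly. What the numbers show is that compound 1 and compound 2, which carry the same naphthalen-2-yl carbonyl as compound 4 but different ether groups, both sit in the high range, whereas compound 3 with its dimethoxyphenyl carbonyl sits very low. Compound 4 is therefore expected to move upward from compound 3 by a sizeable step, a 190-fold higher number from compound 3 to compound 4 (2.28 log units; beyond the scatter), though the ether group of compound 3 is retained and the outcome is uncertain. Compound 4 is estimated at 500 nM, within 30 nM to 8000 nM.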

Compound 4, half-maximal inhibitory concentration: 16.6 nM
Compound 4: middle estimate off by 30-fold (1.48 log units), on the high side; measured number below the stated range.
By their numbers in this assay, from the lowest: compound 3; then compound 4; then compound 2; then compound 1.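

In this assay the carbonyl position accepts a change of ring system with little loss: with the ether group held, naphthalen-2-yl in place of 3,4-dimethoxyphenyl gives a 6.4-fold higher number from compound 3 to compound 4 (0.80 log units; beyond the scatter) and leaves the number low. The large shifts belong to the ether side, since 2,5-dimethoxyphenyl gives a 1100-fold lower number from compound 2 to compound 4 (3.04 log units; beyond the scatter) when it replaces 2-methyl-5-(trifluoromethyl)phenyl and a 3900-fold lower number from compound 1 to compound 4 (3.59 log units; beyond the scatter) when it replaces pentyl, so the naphthalen-2-yl carbonyl alone does not bring a high number. No supporting measurement bears on the reason for any of these shifts.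

Among the compounds shown, the 3,4-dimethoxyphenyl carbonyl appears only with the 2,5-dimethoxyphenyl ether group, so its effect alongside pentyl stays open. Also open, from the compounds shown here alone, are a plain phenyl or 3,4,5-trimethoxyphenyl on the carbonyl carbon, and a plain phenyl in place of 2,5-dimethoxyphenyl on the ether side.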